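This account rests on a few compounds, and the source may have more. Where it says the series, first, only, none or still open, it means among the compounds named here.

Working notes on the pyrazoline series.

In a functional assay on PC-3 cells (Homo sapiens) for cytotoxicity, read by MTT assay, with a stated time of 72 h (on this read-out lower numbers stand for stronger inhibition and higher numbers for weaker inhibition), compound 1 `CNC(=O)c1cc(Oc2ccc(C3=NNC(c4ccc(Cl)cc4Cl)C3)cc2)ccn1` gives 7300 nM. Compound 2 `CNC(=O)c1cc(Oc2ccc(C3=NNC(c4ccc(F)cc4Cl)C3)cc2)ccn1` gives 24300 nM in this assay. The two differ in one place, (chloro in place of fluoro on an aromatic carbon), and the step is a 3.3-fold lower number from compound 2 to compound 1 (0.52 log units; beyond the scatter). Compound 3 `CNC(=O)c1cc(Oc2ccc(C3=NN(C(N)=S)C(c4ccc(F)cc4)C3)cc2)ccn1` has a different core from compound 2; the difference between the two cores is not broken down here. In this assay compound 3 reaches only a limit, > 50000 nM, and no number is known for it. This is the limit of > 50000 nM in this assay, at which 1 of the 3 values shown sits.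

Compound 4 `CNC(=O)c1cc(Oc2ccc(C3=NN(C(N)=S)C(c4ccc(Cl)cc4)C3)cc2)ccn1` is not yet measured. It differs from compound 3 by chloro in place of fluoro on an aromatic carbon. Within the data shown here, this is the same kind of change as the one from compound 2 to compound 1, not the same: there the place was also meta to a chloro group, here it is only para to a large group, and the core carrying the aryl group is the other one. The change is seen twice among these compounds, once measured.

In this assay the step from compound 3 to compound 4 is expected to be an at least 1.6-fold lower number from compound 3 to compound 4 (0.22 log units; that floor lies within the scatter). That expectation rests on the measured step of a 3.3-fold lower number from compound 2 to compound 1 (0.52 log units; beyond the scatter), taken as a guide and read against a starting point that is itself only a limit. Compound 4 is estimated at 30000 nM in this assay, within 10000 nM to 100000 nM. A limit rather than a number remains about as likely because compound 3 sits at the limit of > 50000 nM in this assay, at which 1 of the 3 values shown sits.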

Compound 4, half-maximal inhibitory concentration: > 50000 nM
Compound 4 gave a limit, no number; the forecaster's own chance of this, stated with the estimate: 50%; middle value at least 1.6-fold (0.22 log units) away from the limit.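

In this assay, among these compounds, compound 3 and compound 4 both give only a limit and no number, so no step between them can be read. Both sit at the same limit: the limit of > 50000 nM in this assay, at which 2 of the 4 values shown sit.

The compounds shown leave open whether chloro in place of fluoro on the core of compound 3 lowers the number at all, as it does from compound 2 to compound 1 on the other core.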